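The compounds below may be only part of what the source reports. "The series", "measured", "known", "first", "only" and "open" are said of these compounds alone.

Measured compounds:
compound 1 `CCn1c(=O)c2nc(-c3ccc(S(=O)(=O)N4CCOCC4)cc3)[nH]c2n(CC)c1=O`, in an assay for binding affinity to adenosine receptor A1 (Rattus norvegicus), read by radioligand binding (a lower number here means a stronger inhibitor, a higher number a weaker inhibitor), compound 1 gives 310 nM
compound 2 `CCn1c(=O)c2nc(-c3ccc(S(=O)(=O)NCC(C)O)cc3)[nH]c2n(CC)c1=O`, in this assay compound 2 gives 138 nM

Compound 2 holds the lower of the two numbers in this assay; its nearest neighbour is compound 1, and the step of a 2.2-fold lower number from compound 1 to compound 2 (0.35 log units; beyond the scatter) separates them.

Compound 3 `CCn1c(=O)c2nc(-c3ccc(S(=O)(=O)O)cc3)[nH]c2n(CC)c1=O` is not yet measured. Its difference from compound 2 is hydroxy in place of (2-hydroxypropyl)amino on a sulfonyl sulfur. Among the compounds with values here, the only measured step, a 2.2-fold lower number from compound 1 to compound 2 (0.35 log units; beyond the scatter), exchanges one group for another on the same sulfonyl sulfur, and it was modest. Within the data shown here, the move to compound 3 removes the nitrogen-linked group altogether and leaves a sulfo group; no measured pair covers that kind of change, so the one step bears on it only loosely, as a sign that the group on this sulfur shifts the number by a small amount.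

For compound 3 in this assay the expectation is a step of a 3.3-fold higher number from compound 2 to compound 3 (0.51 log units; beyond the scatter), that is, a number somewhat higher than compound 2 but not far outside the span the two measured compounds already cover. The estimate for compound 3 is 450 nM, with a range from 120 nM to 2500 nM.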

Compound 3, half-maximal inhibitory concentration: 5540 nM
Estimate against measurement, compound 3: 12-fold (1.09 log units) below; the whole stated range lies below it.
By their numbers in this assay, from the lowest: compound 2; then compound 1; then compound 3.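

In this assay the group on the sulfonyl sulfur can move the number much further than the modest 2.2-fold lower number from compound 1 to compound 2 (0.35 log units; beyond the scatter) suggested, with a 40-fold higher number from compound 2 to compound 3 (1.60 log units; beyond the scatter) for the change from (2-hydroxypropyl)sulfamoyl to sulfo and an 18-fold higher number from compound 1 to compound 3 (1.25 log units; beyond the scatter) when hydroxy replaces morpholin-4-yl. Both nitrogen-linked groups, one with a ring and one without, give lower numbers than hydroxy on this sulfur, and the gap between them is far smaller than the gap from either one to compound 3. The reason for the large rise remains unexplained, as no supporting data bear on it.

Open, from the compounds shown here alone, is whether the rise belongs to the sulfo group itself or to the loss of the nitrogen link, a question that an unsubstituted sulfonamide or a carboxylic acid in place of the sulfo group could help separate. Also open, going by these compounds, is how far a longer chain on the sulfonamide nitrogen, or a terminal amine on that chain, would shift the number relative to compound 2.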